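The source may hold more compounds than are shown below. What is called first, only, known or untested is meant among the compounds shown, and "the series" means these compounds.

Compound 1 `O=C(CSc1ncccn1)N/N=c1/scc(-c2ccc(F)cc2)n1-c1ccccc1` gives 110 ug/mL in a functional assay on C6 cells (Rattus norvegicus) for cytotoxicity, read by MTT assay, with a stated time of 24 h; on this read-out higher numbers stand for weaker inhibition and lower numbers for stronger inhibition.
Compound 2 `COc1ccc(-c2cs/c(=N/NC(=O)CSc3ncccn3)n2-c2ccccc2)cc1` gives 102 ug/mL in this assay.
Compound 3 `Cc1ccc(-c2cs/c(=N/NC(=O)CSc3ncccn3)n2-c2ccccc2)cc1` gives 85 ug/mL in this assay.

These three compounds share one core and differ only in the group on one aromatic carbon of the outer phenyl ring. Compound 3 has the lowest of the three numbers, but its neighbours are close: the nearest is compound 2, the furthest compound 1, and both gaps stay within the scatter of repeated measurements, so no order among the three can be claimed.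

Compound 4 `O=C(CSc1ncccn1)N/N=c1/scc(-c2ccc(Cl)cc2)n1-c1ccccc1` is the next member of the series, reached from compound 3 by chloro in place of methyl on an aromatic carbon.

Among the compounds with values here, three measured steps concern the same aromatic carbon: a 1.1-fold lower number from compound 1 to compound 2 (0.03 log units; within the scatter), a 1.3-fold lower number from compound 1 to compound 3 (0.11 log units; within the scatter) and a 1.2-fold lower number from compound 2 to compound 3 (0.08 log units; within the scatter). Each of them swaps one small group for another at this position, and each stays within the scatter. Chloro has not been tested here, but nothing in the three exchanges suggests that a fourth small group at this position should move the number beyond the scatter. The step expected in this assay is therefore a 1.1-fold higher number from compound 3 to compound 4 (0.02 log units; within the scatter), no real change in either direction.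

Compound 4 is estimated at 90 ug/mL, with a likely range from 55 ug/mL to 150 ug/mL.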

Compound 4, half-maximal inhibitory concentration: 83.3 ug/mL
The estimate for compound 4 lay 1.1-fold (0.03 log units) above the measured number; measured number inside the range.
By their numbers in this assay, from the lowest: compounds 4, 3, 2 and 1 (each within the scatter of the next).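

Chloro now joins fluoro, methoxy and methyl at this aromatic carbon in this assay and the picture stays flat: the new steps are a 1.0-fold lower number from compound 3 to compound 4 (0.01 log units; within the scatter) and a 1.2-fold lower number from compound 2 to compound 4 (0.09 log units; within the scatter) and a 1.3-fold lower number from compound 1 to compound 4 (0.12 log units; within the scatter) with no compound among the four going against this. The change from 4-methylphenyl to 4-chlorophenyl puts a chlorine where a carbon stood, and in this series that exchange leaves the number where it was, so a halogen and a small carbon group cannot be told apart at this position. Nothing measured here explains why the four groups read alike.

From the compounds shown here alone, all four compounds carry a small group at this one place, para to a large group, so it remains open whether an amine, a carboxylic acid or a longer chain on the same carbon would move the number beyond the scatter. Going by these compounds, it is also open whether this flat response would hold with chloro moved to another carbon of the ring, or with a change elsewhere on the shared core.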